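The compounds below may be only part of what the source reports. "The series", "measured", "known", "first", "only" and "open" are said of these compounds alone.

Among the compounds with values here, compound 2 `Cc1ccc(OC2CCN(c3ccc(-n4ccnc4)nn3)CC2)cc1` is one of three compounds measured in an assay on microsomes from liver for inhibition of acyl-CoA desaturase 1 (Rattus norvegicus); a lower number here means a stronger inhibitor, a higher number a weaker inhibitor. In this assay compound 2 gives 527 nM, the second highest of the three numbers. Its nearest neighbour is compound 3 `CC(C)(C)c1nnc(-c2ccc(N3CCC(Oc4ccccc4C(F)(F)F)CC3)nn2)s1`, which gives 710 nM in this assay; the two values lie within the usual scatter of each other. Furthest from it is compound 1 `O=C(NCCC1CC1)c1ccc(N2CCC(Oc3ccccc3C(F)(F)F)CC2)nn1`, which gives 14 nM in this assay, a gap well beyond the scatter. Within the data shown here, the only single-point step among the measured compounds is a 51-fold higher number from compound 1 to compound 3 (1.71 log units; beyond the scatter), and it concerns the substituent on an aromatic carbon of the shared core, not the aryl group on the ether oxygen.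

Compound 4 `c1cc(OC2CCN(c3ccc(-n4ccnc4)nn3)CC2)c2cc[nH]c2c1` differs from compound 2 in that place: 1H-indol-4-yl in place of 4-methylphenyl on an oxygen on a saturated carbon. Among the measured compounds shown here, no measured step touches this ether aryl group, so there is no direct guide to the size or direction of the change. On that basis the step from compound 2 to compound 4 is expected to be a 1.3-fold lower number from compound 2 to compound 4 (0.12 log units; within the scatter), small against a wide uncertainty. Compound 4 is therefore estimated at 400 nM in this assay, within a range of 80 nM to 2000 nM.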

Compound 4, half-maximal inhibitory concentration: 162 nM
For compound 4 the middle estimate is 2.5-fold (0.39 log units) above the measured one; low and high end bracket the measured number.
By their numbers in this assay, from the lowest: compound 1; then compound 4; then compounds 2 and 3 (each within the scatter of the next).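

In this assay, the aryl group on the ether oxygen proves able to shift the number on its own: a 3.3-fold lower number from compound 2 to compound 4 (0.51 log units; beyond the scatter) is a step beyond the scatter, with the rest of the molecule unchanged. Within the data shown here, until now the only readable step lay on an aromatic carbon of the core, so this is the first reading at this position. The change adds a five-membered aromatic ring with a hydrogen-bond donor to the carbon-only aromatic ring and removes the methyl group, and nothing at hand explains the effect.

On these data alone, it remains open whether the step follows the ring nitrogen with its hydrogen or simply the second ring, a question that a naphthyl group of carbon only would address. Also open, as far as these compounds go, is whether 1H-indol-4-yl would have a similar effect alongside the (2-cyclopropylethyl)carbamoyl group of compound 1.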